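Longer Ester Chains and Cell Migration at One Concentration

The source may hold more compounds than are shown below. What is called first, only, known or untested is meant among the compounds shown, and "the series" means these compounds.

Three esters sharing one core have been compared in a functional assay on HT-1080 cells (Homo sapiens), read by transwell migration, with a stated time of 24 h, tested at 0.1 uM; a higher number here means a weaker effect of the compound at the concentration tested, a lower number a stronger effect. Compound 1 `CC(=O)OCc1ccc2oc(=O)c(C(=O)Oc3cccc(Br)c3)cc2c1` gives 39.5%. Compound 2 `CCC(=O)OCc1ccc2oc(=O)c(C(=O)Oc3cccc(Br)c3)cc2c1` gives 84.4%, and compound 3 `CCCCC(=O)OCc1ccc2oc(=O)c(C(=O)Oc3cccc(Br)c3)cc2c1` gives 92.4%. The change from compound 1 to compound 2 is methyl in place of hydrogen on a saturated chain carbon bound to a carbonyl carbon, and it made a step of a number 44.9 percentage points higher from compound 1 to compound 2 (beyond the scatter). Compound 3 differs from compound 1 by propyl in place of hydrogen on a saturated chain carbon bound to a carbonyl carbon, with a step of a number 52.9 percentage points higher from compound 1 to compound 3 (beyond the scatter). Between the two longer esters the step is a number 8 percentage points higher from compound 2 to compound 3 (within the scatter).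

Compound 4 `CCCCCC(=O)OCc1ccc2oc(=O)c(C(=O)Oc3cccc(Br)c3)cc2c1` has not yet been measured. It differs from compound 3 by methyl in place of hydrogen on a saturated chain carbon, four bonds along the chain from a carbonyl carbon. This is the same kind of change as that from compound 1 to compound 2, but not the same: there the entering methyl sat on a saturated chain carbon bound to a carbonyl carbon, here it sits four bonds along the chain from a carbonyl carbon. The closer comparison is the chain extension between compound 2 and compound 3, whose step stayed within the scatter. Compound 4 is therefore expected to give 95%, between 83% and 104%, a step of a number 2.6 percentage points higher from compound 3 to compound 4 (within the scatter), because compound 3 already stands at 92.4% and the earlier extension a number 8 percentage points higher from compound 2 to compound 3 (within the scatter) was small.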

Compound 4, a percentage reported as activity, at one concentration (the size of the read-out at that concentration, not a potency): 94.3%
Beside the measured number, compound 4's estimate is 0.7 percentage points above it; measured number inside the range.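

In this assay, the ester chain reaches a plateau after the first extension: the new compound gives a step of a number 1.9 percentage points higher from compound 3 to compound 4 (within the scatter), while the wider comparisons give a number 9.9 percentage points higher from compound 2 to compound 4 (within the scatter) and a number 54.8 percentage points higher from compound 1 to compound 4 (beyond the scatter). Swapping hydrogen for methyl therefore does not carry a fixed effect from one core to another in this series, and its size depends on the chain it is made on: the same change on two cores in this assay, a number 44.9 percentage points higher (beyond the scatter) from compound 1 to compound 2 and a number 1.9 percentage points higher (within the scatter) from compound 3 to compound 4, 43 percentage points apart, beyond the scatter of two such steps The data do not show why the two steps differ, nor do they give a rule beyond these compounds, and the propyl change tells the same story: the same change on two cores in this assay, a number 52.9 percentage points higher (beyond the scatter) from compound 1 to compound 3 and a number 9.9 percentage points higher (within the scatter) from compound 2 to compound 4, 43 percentage points apart, beyond the scatter of two such steps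

The compounds shown leave open whether a longer chain than that of compound 4 would stay at this level, and whether an amine or a carboxylic acid on the ester chain would bring the number back down. Going by these compounds, each result comes from a single concentration, so how these compounds compare at other concentrations also remains open.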